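The source may report more compounds than this note shows. Statements on the series, on what has been measured and on what is new or still open speak of the compounds shown alone.

Measured compounds:
- compound 1, `O=c1[nH]c(=O)n(CCC(CO)CO)cc1-c1cccs1`, 6000 nM
- compound 2, `CCCCCc1ccc(C#Cc2cn(CCC(COC(C)=O)COC(C)=O)c(=O)n(C(=O)c3ccccc3)c2=O)cc1`, 100 nM
- compound 3, `CC(=O)OCC(CCn1cc(C#CCc2ccccc2)c(=O)n(C(=O)c2ccccc2)c1=O)COC(C)=O`, 26800 nM

In a functional assay on MCF7 cells (Homo sapiens) for antiproliferative activity, read by MTT assay, with a stated time of 72 h (on this read-out lower numbers stand for stronger inhibition and higher numbers for weaker inhibition), compound 2 gives 100 nM, the lowest number of the three. Compound 1 stands nearest to it, and compound 3 stands furthest from it, as the values above show. Within the data shown here, the one step that replaces the 4-pentylphenyl of compound 2 on a triple-bonded carbon, a 270-fold higher number from compound 2 to compound 3 (2.43 log units; beyond the scatter), is large and beyond the scatter.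

Compound 4, `CC(=O)OCC(CCn1cc(C#CCCCCl)c(=O)n(C(=O)c2ccccc2)c1=O)COC(C)=O`, has not yet been measured in this assay. It differs from compound 2 by 3-chloropropyl in place of 4-pentylphenyl on a triple-bonded carbon. The step from compound 2 to compound 3 bears directly on it, since both changes remove the same 4-pentylphenyl from the same triple-bonded carbon; in that step the number rose steeply. On this basis a large rise in this assay is expected for compound 4 as well, in the same direction, described by a 120-fold higher number from compound 2 to compound 4 (2.08 log units; beyond the scatter). Among the measured compounds shown here, compound 4 is therefore estimated at 12000 nM, with a plausible range from 2500 nM to 60000 nM, the precise size being uncertain because only one comparable step, a 270-fold higher number from compound 2 to compound 3 (2.43 log units; beyond the scatter), is available.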

Compound 4, half-maximal inhibitory concentration: 21000 nM
The estimate for compound 4 lay 1.8-fold (0.24 log units) below the measured number; the range from low to high includes it.
By their numbers in this assay, from the lowest: compound 2; then compound 1; then compounds 4 and 3 (each within the scatter of the next).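

In this assay, replacing the 4-pentylphenyl on the triple-bonded carbon with a group that has no ring gives a 210-fold higher number from compound 2 to compound 4 (2.32 log units; beyond the scatter), so the large rise seen with the benzyl of compound 3 is not confined to that one replacement. The two replacements end up level: a 1.3-fold lower number from compound 3 to compound 4 (0.11 log units; within the scatter) lies within the scatter, and on the saturated chain carbon bound to the triple-bonded carbon, 2-chloroethyl and phenyl cannot be told apart in this read-out. Among the three compounds that differ at this position, only compound 2, with its 4-pentylphenyl, reaches the low number, and no measurement at hand explains this.

On these data alone, it remains open whether the low number of compound 2 goes with the aromatic ring or with the pentyl chain it carries, and a plain phenyl or a straight decyl chain on the triple-bonded carbon would separate the two. Also open, as far as these compounds go, is whether anything on the saturated chain matters at all, for instance an amine or a hydroxyl in place of the chlorine of the 3-chloropropyl.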